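Swapping an amide for a sulfonamide on a shared core

A few compounds are considered here, and "the series" means these few. Any claim that something is new, unique, unknown or untested is made for them only; others in the source may bear on it.

Measured compounds:
- compound 1, `O=C(/C=C/c1cccc(NC(=O)c2ccccc2Br)c1)c1nc2ccccc2[nH]1`, 4520 nM
- compound 2, `Cc1cccc(C(=O)Nc2cccc(/C=C/C(=O)c3nc4ccccc4[nH]3)c2)c1`, 5590 nM
- compound 3, `Cc1ccc(C(=O)Nc2cccc(/C=C/C(=O)c3nc4ccccc4[nH]3)c2)cc1`, 9690 nM

All three were tested in a functional assay on MCF7 cells (Homo sapiens) for antiproliferative activity, read by MTT assay, with a stated time of 48 h; on this read-out higher numbers stand for weaker inhibition and lower numbers for stronger inhibition. Compound 3 has the highest number of the three. Its step to compound 2 is small, a 1.7-fold higher number from compound 2 to compound 3 (0.24 log units; within the scatter), and so within the scatter, while its step from compound 1 is larger, a 2.1-fold higher number from compound 1 to compound 3 (0.33 log units; beyond the scatter), and modest but beyond the scatter.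

Compound 4, `O=C(/C=C/c1cccc(NS(=O)(=O)c2cccc(Cl)c2)c1)c1nc2ccccc2[nH]1`, has not yet been measured. It differs from compound 3 in one place: (3-chlorophenyl)sulfonyl in place of (4-methylphenyl)carbonyl on a nitrogen on an aromatic ring.

Going by the values given here, none of the measured steps changes the carbonyl itself; they only exchange the aryl group attached to it. Those steps, a 1.2-fold higher number from compound 1 to compound 2 (0.09 log units; within the scatter), a 2.1-fold higher number from compound 1 to compound 3 (0.33 log units; beyond the scatter) and a 1.7-fold higher number from compound 2 to compound 3 (0.24 log units; within the scatter), were all small or modest. Compound 1, which carries a halogenated aryl group, gave the lowest number of the three. Among the compounds with values here, on this basis a small change is expected in this assay for compound 4, most likely a slightly lower number than compound 3, though the carbonyl-to-sulfonyl swap has no precedent here and widens the uncertainty.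

Compound 4 is therefore estimated at 6000 nM, with a range from 2000 nM to 20000 nM, a step of a 1.6-fold lower number from compound 3 to compound 4 (0.21 log units; within the scatter) that is expected to stay close to the scatter.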

Compound 4, half-maximal inhibitory concentration: 4160 nM
For compound 4 the middle estimate is 1.4-fold (0.16 log units) above the measured one, within the range that was stated.
By their numbers in this assay, from the lowest: compounds 4, 1, 2 and 3 (each within the scatter of the next, the first and the last beyond it).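

The result shows that a carbonyl is not required on this nitrogen: a sulfonyl group carrying an aryl ring also gives a measurable effect in this assay. The change to (3-chlorophenyl)sulfonyl gives a 2.3-fold lower number from compound 3 to compound 4 (0.37 log units; beyond the scatter), a modest step, whereas a 1.3-fold lower number from compound 2 to compound 4 (0.13 log units; within the scatter) and a 1.1-fold lower number from compound 1 to compound 4 (0.04 log units; within the scatter) are steps too small to place these compounds in any order. Nothing available here explains these numbers at the level of mechanism or physical properties.

Each of these steps changes the linking group and the aryl ring together, so the contributions of the sulfonyl and the chlorine remain unresolved, and a (4-methylphenyl)sulfonyl group on the same nitrogen would be the direct partner of the group in compound 3 for separating them. On these data alone, it also remains open whether the aryl ring on the sulfonyl is needed at all, which a methyl group in its place would test, and how a ring bearing an amine or a carboxylic acid would behave at this position.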